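Methoxy-to-hydroxy step in a flavone side-chain series

The source may report more compounds than this note shows. Statements on the series, on what has been measured and on what is new or still open speak of the compounds shown alone.

Three compounds of the series carry a measured value in a functional assay on BCG823 cells (Homo sapiens) for antiproliferative activity, read by MTT assay, with a stated time of 48 h; on this read-out lower numbers stand for stronger inhibition and higher numbers for weaker inhibition. Compound 1 `O=c1cc(-c2ccccc2)oc2cc(O)c(OCCCCN3CCCCC3)c(O)c12` gives 52700 nM. Compound 2 `COc1cc2oc(-c3ccccc3)cc(=O)c2c(O)c1OCCCCN1CCCCC1` gives 21900 nM. Compound 3 `COc1cc2oc(-c3ccccc3)cc(=O)c2c(O)c1OCCCN1CCCC1` gives 6500 nM, the lowest number of the three.

Two single-point steps connect them. From compound 2 to compound 1 the change is hydrogen in place of methyl on an oxygen on an aromatic ring, and it reads a 2.4-fold higher number from compound 2 to compound 1 (0.38 log units; beyond the scatter). From compound 2 to compound 3 the change is pyrrolidin-1-yl in place of (piperidin-1-yl)methyl on a saturated chain carbon, three bonds along the chain from an oxygen on an aromatic ring, and it reads a 3.4-fold lower number from compound 2 to compound 3 (0.53 log units; beyond the scatter).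

Compound 4 `O=c1cc(-c2ccccc2)oc2cc(O)c(OCCCN3CCCC3)c(O)c12` is not yet measured. It differs from compound 3 by hydrogen in place of methyl on an oxygen on an aromatic ring, the same change that was made from compound 2 to compound 1, at a place described in the same words. The cores of compound 3 and compound 4 differ from those of compound 2 and compound 1 by pyrrolidin-1-yl in place of (piperidin-1-yl)methyl on a saturated chain carbon, three bonds along the chain from an oxygen on an aromatic ring carried over unchanged.

Among the measured compounds shown here, for compound 4 the step in this assay is expected to be about a 2.4-fold higher number from compound 3 to compound 4 (0.38 log units; beyond the scatter), resting on the one earlier instance of this change, a 2.4-fold higher number from compound 2 to compound 1 (0.38 log units; beyond the scatter). Compound 4 is therefore estimated at 15600 nM, with a plausible range of 7000 nM to 35000 nM.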

Compound 4, half-maximal inhibitory concentration: > 100000 nM
Compound 4: only a limit was reported; the forecaster's own chance of this, stated with the estimate: 5%; at least 6.4-fold (0.80 log units) between middle value and limit.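

In this assay compound 4 gives > 100000 nM, a limit of the assay and not a number. Methoxy to hydroxy raises the number on both cores, but it does not carry over at a constant size, and the step on this core, an at least 15-fold higher number from compound 3 to compound 4 (1.18 log units; beyond the scatter), is only a floor, so its true size stays unknown: the same change on two cores in this assay, a 2.4-fold higher number (0.38 log units; beyond the scatter) from compound 2 to compound 1 and an at least 15-fold higher number (1.18 log units; beyond the scatter) from compound 3 to compound 4, at least 6.3-fold (0.80 log units) apart, beyond the scatter of two such steps The side-chain change does not carry over either, since its earlier lowering is not repeated on the hydroxy core, where an at least 1.8-fold higher number from compound 1 to compound 4 (0.27 log units; that floor lies within the scatter) leaves open whether any real change occurs, and a single pair of cores gives no general rule: the same change on two cores in this assay, a 3.4-fold lower number (0.53 log units; beyond the scatter) from compound 2 to compound 3 and an at least 1.8-fold higher number (0.27 log units; that floor lies within the scatter) from compound 1 to compound 4, at least 6.3-fold (0.80 log units) apart, beyond the scatter of two such steps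

The side-chain change alters both the ring and the chain together, so the compounds shown do not tell which of the two goes with the larger step; piperidin-1-yl on the chain of compound 3, or pyrrolidin-1-yl on the chain of compound 2, would separate them. Also open, as far as these compounds go, is how an ethoxy group in place of the methoxy group would read on either core.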